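Quinolinyl Ether in Place of a Dichloropyridazinyl Ether

This account rests on a few compounds, and the source may have more. Where it says the series, first, only, none or still open, it means among the compounds named here.

Compound 3 `CC(C)[C@H](NC(=O)COc1cccc2ccccc12)C(=O)N[C@@H](CC(=O)O)C(=O)COc1nncc(Cl)c1Cl` was tested in a functional assay on Jurkat cells (Homo sapiens) for inhibition; a higher number here means a weaker inhibitor, a lower number a stronger inhibitor. In this assay compound 3 gives > 200000 nM, which is a limit of the assay and not a number. Two companions share the same core and differ from compound 3 only in the group hanging from the carbonyl-bearing chain carbon. Compound 1 `CC(C)[C@H](NC(=O)COc1cccc2ccccc12)C(=O)N[C@@H](CC(=O)O)C(=O)CSc1nc2ccccc2[nH]1` gives in this assay > 200000 nM, also a limit. Compound 2 `CC(C)[C@H](NC(=O)COc1cccc2ccccc12)C(=O)N[C@@H](CC(=O)O)C(=O)CSc1nc2ccccc2s1` gives in this assay > 200000 nM, again a limit. The steps among these three, a step that the two limits leave unreadable from compound 1 to compound 2, a step that the two limits leave unreadable from compound 1 to compound 3 and a step that the two limits leave unreadable from compound 2 to compound 3, cannot be sized because of the limit of > 200000 nM in this assay, at which 3 of the 3 values shown sit.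

Compound 4 `CC(C)[C@H](NC(=O)COc1cccc2ccccc12)C(=O)N[C@@H](CC(=O)O)C(=O)COc1cccc2cccnc12` differs from compound 3 in one place: quinolin-8-yl in place of 4,5-dichloropyridazin-3-yl on an oxygen on a saturated carbon. For the measured compounds named here, no measured step offers a readable size for such a change, so the expected step that the limit leaves unreadable from compound 3 to compound 4 rests on the limits alone and carries no direction beyond the scatter. Compound 4 is therefore expected to give about 300000 nM in this assay, with a range from 40000 nM to 2000000 nM, and most likely again only a limit.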

Compound 4, half-maximal inhibitory concentration: > 200000 nM
Compound 4 was reported as a limit; the forecaster's own chance of this, stated with the estimate: 75%; the middle value lies beyond the limit too.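

In this assay compound 4 gives > 200000 nM, a limit and not a number. No step among compound 1, compound 2, compound 3 and compound 4 can be read, because all of them sit at one limit: the limit of > 200000 nM in this assay, at which 4 of the 4 values shown sit.

From the compounds shown here alone, whether these four compounds truly differ from one another in this assay stays open.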